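The source may hold more compounds than are shown below. What is called first, only, known or untested is meant among the compounds shown, and "the series" means these compounds.

Working notes on the series.

Compound 1, `Cc1ccc(-c2cc3nc(-c4ccc(F)cc4)cc(N)n3n2)cc1`, gives 65% in a functional assay on the whole organism (strain Wistar) for inhibition, with Rattus norvegicus as the target, read by paw edema, with stated times of 30 min and 2 h, at a dose of 50 mg/kg by the oral route; on this read-out higher numbers stand for more inhibition at the one dose given (going by the name of the read-out) and lower numbers for less inhibition. Within the data shown here, compound 3, `Cc1ccc(-c2cc3nc(-c4ccc(Br)cc4)cc(N)n3n2)cc1`, gives 56.3%, which puts it second highest of the three numbers so far: its nearest neighbour is compound 1, and the only single-point step measured, a number 8.7 percentage points lower from compound 1 to compound 3 (within the scatter), lies within the scatter. Compound 2, `Nc1cc(-c2ccc(Cl)cc2)nc2cc(-c3ccccc3)nn12`, gives 13.8% and stands far below both, but it differs from compound 3 in more than one place, so no single step can be read from it.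

Compound 4, `Cc1ccc(-c2cc3nc(-c4ccc(Cl)cc4)cc(N)n3n2)cc1`, differs from compound 3 by chloro in place of bromo on an aromatic carbon. Among the measured compounds shown here, the one step that bears on this change is the exchange of halogens at the same place, a number 8.7 percentage points lower from compound 1 to compound 3 (within the scatter), which did not move the read-out beyond the scatter. Chloro sits between fluoro and bromo among the halogens already tried, and nothing in the measured pairs points to a direction for it. The step of a number 3.7 percentage points higher from compound 3 to compound 4 (within the scatter) is therefore expected to stay within the scatter. Compound 4 is estimated at 60% in this assay, with a likely range from 45% to 72%.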

Compound 4, a percentage reported as inhibition, in the whole organism at one dose (the size of the read-out at that dose, not a potency): 67.5%
The estimate for compound 4 lay 7.5 percentage points below the measured number, within the range that was stated.
By their numbers in this assay, from the lowest: compound 2; then compounds 3, 1 and 4 (each within the scatter of the next, the first and the last beyond it).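

Among these compounds, the exchange of 4-bromophenyl to 4-chlorophenyl gives the first halogen step at this position that lies beyond the scatter (a number 11.2 percentage points higher from compound 3 to compound 4 (beyond the scatter)) in this assay, although the step is only modest, while the chloro and fluoro compounds are not separated (a number 2.5 percentage points higher from compound 1 to compound 4 (within the scatter)), so the position shows some sensitivity to the halogen but no simple order across the three. With chloro on the ring in both compounds, methyl in place of hydrogen on an aromatic carbon gives a large step (a number 53.7 percentage points higher from compound 2 to compound 4 (beyond the scatter)), far greater than either halogen step here, so in this pair that change matters much more than the choice of halogen. Nothing at hand gives a reason for any of these steps.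

Open, as far as these compounds go, is whether the effect of the methyl holds with fluoro or bromo on the other ring, and whether a longer chain such as ethyl can take the place of methyl. Also open, from the compounds shown here alone, is how a non-halogen group at the halogen position, such as methoxy, an amine or a carboxylic acid, would read in this assay.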